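Lipophilicity notes: sulfonyl-linked amine tail, compound 3 to compound 4

The source may hold more compounds than are shown below. What is called first, only, known or untested is meant among the compounds shown, and "the series" means these compounds.

Measured so far in a physicochemical assay for lipophilicity; a lower number here means a more polar compound, a higher number a more lipophilic compound:
compound 1 `COCCNCCCS(=O)(=O)c1ccc2nc(NC(=O)NC(=O)c3ccccc3Cl)sc2c1` — 1.3
compound 2 `CN1CCN(CCCS(=O)(=O)c2ccc3nc(NC(=O)NC(=O)c4cc(-n5cccc5)ccc4Cl)sc3c2)CC1` — 2.6
compound 3 `CC(C)NCCS(=O)(=O)c1ccc2nc(NC(=O)NC(=O)c3ccccc3Cl)sc2c1` — 2.3

Compound 3 stands second highest of the three numbers. Its nearest neighbour is compound 2, which lies within the scatter of it; compound 1 lies furthest, beyond the scatter. For the measured compounds named here, the one single-point step in the set is a number 1.00 log units higher from compound 1 to compound 3 (beyond the scatter): an isopropylamino in place of a ((2-methoxyethyl)amino)methyl on a saturated chain carbon, two bonds along the chain from a sulfonyl sulfur.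

Compound 4 `CCN(CC)CCCS(=O)(=O)c1ccc2nc(NC(=O)NC(=O)c3ccccc3Cl)sc2c1` is not yet measured. It differs from compound 3 as follows: (diethylamino)methyl in place of isopropylamino on a saturated chain carbon, two bonds along the chain from a sulfonyl sulfur. Isopropylamino leaves, (diethylamino)methyl enters, at the same place as the change from compound 1 to compound 3. Going by the values given here, no measured step covers this exact exchange; the step from compound 1 to compound 3 is the only one at this position and shows that changes there can move the number beyond the scatter. Given that compound 3 gives 2.3 in this assay, the number for compound 4 is expected to rise modestly, an estimated step of a number 0.40 log units higher from compound 3 to compound 4 (beyond the scatter). Compound 4 is therefore estimated at 2.7, with a range from 2.2 to 3.2.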

Compound 4, distribution coefficient: 1.7
Beside the measured number, compound 4's estimate is 1.00 log units above it, and the stated range ends above it.
By their numbers in this assay, from the lowest: compound 1; then compound 4; then compounds 3 and 2 (each within the scatter of the next).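

Read in this assay this position now moves the number in both directions, with a number 1.00 log units higher from compound 1 to compound 3 (beyond the scatter) and then a number 0.60 log units lower from compound 3 to compound 4 (beyond the scatter) for the exchange of isopropylamino for (diethylamino)methyl. For the compounds shown here, the drop comes with a larger group, 6 heavy atoms against 4, and with 0 hydrogen-bond donors against 1, so among compounds 1, 3 and 4 the number does not rise with the heavy-atom count of the entering group, and a number 0.40 log units higher from compound 1 to compound 4 (beyond the scatter) places diethylamino in place of (2-methoxyethyl)amino on a smaller upward step than the one to compound 3. Nothing measured here accounts for the fall at compound 4.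

Read one bond further out, the exchange is 2-(isopropylamino)ethyl to 3-(diethylamino)propyl, so the length of the chain and the substitution on the amine change together, and the compounds shown leave open which of the two carries the step. A 3-(isopropylamino)propyl or a 2-(diethylamino)ethyl tail on the same core would separate them.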